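Aryl swap on the shorter-chain core: expectation for compound 4

This account rests on a few compounds, and the source may have more. Where it says the series, first, only, none or still open, it means among the compounds named here.

Three measured compounds share a core: compound 1 `CCCCCCn1cnc2c(Nc3ccc(Cl)cc3)nc(N[C@H]3CC[C@H](N)CC3)nc21`, compound 2 `CCCCCCn1cnc2c(Nc3cc(OC)cc(OC)c3)nc(N[C@H]3CC[C@H](N)CC3)nc21` and compound 3 `CCCCn1cnc2c(Nc3cc(OC)cc(OC)c3)nc(N[C@H]3CC[C@H](N)CC3)nc21`. In a functional assay on BT-474 cells (Homo sapiens) for inhibition, read by fluorescence, with a stated time of 72 h (a lower number here means a stronger inhibitor of growth, a higher number a weaker inhibitor of growth), compound 1 gives 5500 nM, compound 2 gives 3700 nM and compound 3 gives 15600 nM. Compound 4 `CCCCn1cnc2c(Nc3ccc(Cl)cc3)nc(N[C@H]3CC[C@H](N)CC3)nc21` is not yet measured.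

Compound 2 and compound 3 differ in the core by hydrogen in place of ethyl on a saturated chain carbon, four bonds along the chain from an aromatic nitrogen, a step of a 4.2-fold higher number from compound 2 to compound 3 (0.62 log units; beyond the scatter). Compound 2 and compound 1 differ by 4-chlorophenyl in place of 3,5-dimethoxyphenyl on a nitrogen on an aromatic ring, giving a 1.5-fold higher number from compound 2 to compound 1 (0.17 log units; within the scatter). The same change, at the same place, turns compound 3 into compound 4: 4-chlorophenyl in place of 3,5-dimethoxyphenyl on a nitrogen on an aromatic ring.

For compound 4 the expected step is a 1.4-fold higher number from compound 3 to compound 4 (0.15 log units; within the scatter), because the earlier instance gave a 1.5-fold higher number from compound 2 to compound 1 (0.17 log units; within the scatter). In this assay compound 4 is therefore estimated at 22000 nM, with an expected range from 9000 nM to 50000 nM.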

Compound 4, concentration for 50% growth inhibition: 7300 nM
Compound 4: middle estimate off by 3.0-fold (0.48 log units), on the high side; measured number below the stated range.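

In this assay the change to 4-chlorophenyl from 3,5-dimethoxyphenyl gives a 2.1-fold lower number from compound 3 to compound 4 (0.33 log units; beyond the scatter) on the shorter-chain core, so the step does not carry over unchanged from the longer-chain core: the same change on two cores in this assay, a 1.5-fold higher number (0.17 log units; within the scatter) from compound 2 to compound 1 and a 2.1-fold lower number (0.33 log units; beyond the scatter) from compound 3 to compound 4, 3.2-fold (0.50 log units) apart, beyond the scatter of two such steps The shorter chain likewise has a different effect with 4-chlorophenyl on the aromatic amine, giving a 1.3-fold higher number from compound 1 to compound 4 (0.12 log units; within the scatter): the same change on two cores in this assay, a 4.2-fold higher number (0.62 log units; beyond the scatter) from compound 2 to compound 3 and a 1.3-fold higher number (0.12 log units; within the scatter) from compound 1 to compound 4, 3.2-fold (0.50 log units) apart, beyond the scatter of two such steps The two changes therefore do not add independently across compounds 1 to 4, but this square does not show why, nor which step is more typical of the series.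

Still open, going by these compounds, is whether this dependence holds with an unsubstituted phenyl on that nitrogen. The same applies to a chain longer than hexyl on the aromatic nitrogen.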